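The compounds below may be only part of what the source reports. "The series", "measured", "known", "first", "only" and "open" are said of these compounds alone.

Measured compounds:
compound 1, `Oc1ccccc1-c1cc(-c2ccccc2F)cc(-c2ccccc2O)n1`, > 50000 nM
compound 2, `Oc1ccc(-c2cc(-c3ccccc3F)cc(-c3ccccc3O)n2)cc1`, > 50000 nM

In a functional assay on HeLa cells (Homo sapiens) for inhibition (on this read-out higher numbers stand for weaker inhibition and lower numbers for stronger inhibition), compound 1 gives only a limit of the assay and not a number, namely > 50000 nM. Compound 2 likewise gives only a limit, > 50000 nM. Among the measured compounds shown here, the one measured step, a step that the two limits leave unreadable from compound 1 to compound 2, is 4-hydroxyphenyl in place of 2-hydroxyphenyl on an aromatic carbon, and its size cannot be read, because of the limit of > 50000 nM in this assay, at which 2 of the 2 values shown sit.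

Compound 3, `Oc1ccccc1-c1cc(-c2ccccc2C(F)(F)F)cc(-c2ccccc2O)n1`, has not yet been measured in this assay. It differs from compound 1 by trifluoromethyl in place of fluoro on an aromatic carbon; cut one bond further out, the difference reads 2-fluorophenyl to 2-(trifluoromethyl)phenyl. For the measured compounds named here, no measured step touches this position, and the only step in hand is itself unreadable, so there is nothing to show a shift in either direction beyond the scatter.

Compound 3 is therefore expected to sit where compound 1 sits, most likely again at the limit, with an estimate of 50000 nM and a range from 20000 nM to 100000 nM. Going by the values given here, the step this implies, a number no higher from compound 1 to compound 3 (the limit leaves the size open), is expected to be no step at all.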

Compound 3, half-maximal inhibitory concentration: 5800 nM
Compound 3: middle estimate off by 8.6-fold (0.94 log units), on the high side; the whole stated range lies above it.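

The position held by fluoro in compound 1 is not silent in this assay: trifluoromethyl in place of fluoro on this aromatic carbon, ortho to a large group, gives an at least 8.6-fold lower number from compound 1 to compound 3 (0.93 log units; beyond the scatter), and a lower number here stands for stronger inhibition. With 5800 nM, compound 3 is the first of the compounds shown to give a number rather than a limit, so a single change at this position is enough to bring the series into the measurable range of this assay. This position therefore gives the first readable structure-activity information, whereas the step between the 2-hydroxyphenyl and 4-hydroxyphenyl compounds still cannot be read, because of what the assay's limit leaves hidden: the limit of > 50000 nM in this assay, at which 2 of the 3 values shown sit.

The compounds shown leave open how other groups would read at the same place, such as an amine, a carboxylic acid, a methoxy group or a longer chain, and so whether this gain belongs to trifluoromethyl alone. They also leave open whether the same change would bring a number on the 4-hydroxyphenyl compound, compound 2, and what feature of the group carries the step, which a single pair cannot separate.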